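Swapping the Piperidine Amide for a Small Amino Acid

This account rests on a few compounds, and the source may have more. Where it says the series, first, only, none or still open, it means among the compounds named here.

Compound 3 `COc1ccc(/C=C\c2cc(OC)c(OC)c(OC)c2)cc1OCc1ccc(CN2CCCCC2C(=O)NCCN)cc1` stands lowest of the two numbers in a functional assay on HeLa cells (Homo sapiens) for antiproliferative activity, read by CCK-8 assay, with a stated time of 48 h (on this read-out lower numbers stand for stronger inhibition and higher numbers for weaker inhibition), where compound 3 gives 7300 nM. Compound 2 `COc1ccc(/C=C\c2cc(OC)c(OC)c(OC)c2)cc1OCc1ccc(CN2CCCCC2C(=O)O)cc1` gives 14200 nM, a 1.9-fold lower number from compound 2 to compound 3 (0.29 log units; within the scatter). Compound 1 `COc1ccc(/C=C\c2cc(OC)c(OC)c(OC)c2)cc1OCc1ccc(CN[C@H](C(=O)O)[C@H](C)O)cc1` gives only a limit, > 10000 nM. The position of that limit is the limit of > 10000 nM in this assay, at which 1 of the 3 values shown sits. Compound 4 `COc1ccc(/C=C\c2cc(OC)c(OC)c(OC)c2)cc1OCc1ccc(CNC(C)(C)C(=O)O)cc1` differs from compound 3 by (1-carboxy-1-methylethyl)amino in place of 2-((2-aminoethyl)carbamoyl)piperidin-1-yl on a saturated chain carbon bound to an aromatic carbon. Among the compounds with values here, the steps that bear on this change are an at least 1.3-fold lower number from compound 1 to compound 3 (0.13 log units; that floor lies within the scatter) and a 1.9-fold lower number from compound 2 to compound 3 (0.29 log units; within the scatter): both compounds bearing a carboxylic acid give either a limit or a number within the scatter of compound 3. Because a 1.9-fold lower number from compound 2 to compound 3 (0.29 log units; within the scatter) is small, the expected change for compound 4 is a 2.1-fold higher number from compound 3 to compound 4 (0.31 log units; beyond the scatter), a modest move toward weaker inhibition. Compound 4 is therefore estimated at 15000 nM, within a range from 6000 nM to 40000 nM.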

Compound 4, half-maximal inhibitory concentration: > 10000 nM
Compound 4 ended at the assay's limit; the forecaster's own chance of this, stated with the estimate: 40%; the middle value lies beyond the limit too.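

Replacing the piperidine amide of compound 3 with (1-carboxy-1-methylethyl)amino gives an at least 1.3-fold higher number from compound 3 to compound 4 (0.13 log units; that floor lies within the scatter), so this small open-chain amino acid brings no readable gain at this position. The steps from compound 1 and compound 2 to compound 4 cannot be read, and a second compound now sits at the limit: the limit of > 10000 nM in this assay, at which 2 of the 4 values shown sit.

As far as these compounds go, whether a methyl ester in place of the carboxylic acid of compound 4, or a longer chain ending in an amine, would bring the number under that limit stays open.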